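Phenyl in Place of Methyl: What to Expect of Compound 4

A few compounds are considered here, and "the series" means these few. Any claim that something is new, unique, unknown or untested is made for them only; others in the source may bear on it.

In a functional assay on MDA-MB-231 cells (Homo sapiens) for inhibition, read by MTT assay, with a stated time of 72 h (a higher number here means a weaker inhibitor, a lower number a stronger inhibitor), compound 1 `COC(=O)c1ccc(-c2nnn(CCCOS(=O)(=O)c3ccc(C)cc3)n2)cc1` gives > 100000 nM. That value is a limit of the assay and not a number.

Compound 2 `COC(=O)c1ccc(-c2cn(CCCC(=O)Nc3ccc(C)cc3)nn2)cc1` gives 2700 nM, and compound 3 `Cc1ccc(NC(=O)CCCn2cc(-c3ccc(C(F)(F)F)cc3)nn2)cc1` gives 2300 nM. Going by the values given here, these two values lie within the scatter of each other, so compound 3 stands level with compound 2, and they are the only true numbers so far.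

Compound 4 `O=C(CCCn1cc(-c2ccc(C(F)(F)F)cc2)nn1)Nc1ccc(-c2ccccc2)cc1` differs from compound 3 in one place: phenyl in place of methyl on an aromatic carbon. This is phenyl in place of methyl on an aromatic carbon, para to a large group.

Among the compounds with values here, no measured step touches that place. Within the data shown here, the only measured step, a 1.2-fold lower number from compound 2 to compound 3 (0.07 log units; within the scatter), is trifluoromethyl in place of methoxycarbonyl on an aromatic carbon, a change at a different group, and it stays within the scatter. It shows that one swap elsewhere left the number unmoved, but it gives no size for the present change.

The expectation therefore starts from compound 3 at 2300 nM, with no shift beyond the scatter and a wide margin on either side. The expected step is a 1.2-fold lower number from compound 3 to compound 4 (0.06 log units; within the scatter). The estimated value for compound 4 is 2000 nM, with an expected range from 600 nM to 8000 nM.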

Compound 4, half-maximal inhibitory concentration: 2000 nM
Compound 4: middle estimate and measured number agree at the digits printed, within the range that was stated.
By their numbers in this assay, from the lowest: compounds 4, 3 and 2 (each within the scatter of the next). At a limit, above all of these: compound 1.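

In this assay this position now has a measured step of its own: a 1.2-fold lower number from compound 3 to compound 4 (0.06 log units; within the scatter). Methyl, with 1 heavy atom, gives way to phenyl, with 6 heavy atoms and a six-membered aromatic ring of carbon only, and the number stays level, which shows that this aromatic carbon, para to a large group, carries the added ring with no change beyond the scatter in this read-out. The earlier compounds shown here gave one such level step, at a different group: a 1.2-fold lower number from compound 2 to compound 3 (0.07 log units; within the scatter). Compound 4 now adds a second place where a single swap leaves the number unmoved.

The compounds shown leave open whether this level result holds only for groups of carbon alone, since an amine or a carboxylic acid at this place could behave differently. They also leave open whether a single step at the chain between the amide carbonyl and the shared core, such as a longer chain, would move the number beyond the scatter. Nothing measured here bears on why the number stays level.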